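Series notes: step from compound 2 to compound 3

The source may hold more compounds than are shown below. What is called first, only, known or untested is meant among the compounds shown, and "the series" means these compounds.

Measured in an ADME assay on the whole organism (Mus musculus, strain CD-1) for pharmacokinetics; a higher number here means faster removal of the compound, a lower number slower removal:
- compound 1 `COc1cc([C@](O)(CCN(C)C)[C@@H](c2cc3cc(Br)ccc3nc2OC)c2cccc(OC)c2F)cc(SC)n1`: 13 mL/min/kg
- compound 2 `COc1cccc([C@H](c2cc3cc(Br)ccc3nc2OC)[C@@](O)(CCN(C)C)c2cc(SC)nc(SC)c2)c1F`: 13 mL/min/kg

Compound 2 stands level with compound 1 in this assay, with compound 2 at 13 mL/min/kg. Compound 3 `CCSc1cc([C@](O)(CCN(C)C)[C@@H](c2cc3cc(Br)ccc3nc2OC)c2cccc(OC)c2F)cc(SCC)n1` carries a group of 12 heavy atoms (9 carbon, 1 nitrogen, 2 sulfur; one six-membered aromatic ring with 1 hetero atom) in place of a group of 10 heavy atoms (7 carbon, 1 nitrogen, 2 sulfur; one six-membered aromatic ring with 1 hetero atom), on a saturated chain carbon bound to an oxygen on a saturated carbon and two saturated chain carbons. Within the data shown here, one measured step bears on this, methylsulfanyl in place of methoxy on an aromatic carbon, and it shows no change at the digits printed from compound 1 to compound 2 (within the scatter). Among the measured compounds shown here, that is a different exchange and only a single step, so it guides weakly. No move beyond the scatter is expected, in either direction. The expected step is no change at the digits printed from compound 2 to compound 3 (within the scatter). Compound 3 is estimated at 13 mL/min/kg, within a range of 7 mL/min/kg to 25 mL/min/kg.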

Compound 3, clearance: 3.6 mL/min/kg
Beside the measured number, compound 3's estimate is 3.6-fold (0.56 log units) above it; the measured number lies below the stated range.
By their numbers in this assay, from the lowest: compound 3; then compounds 1 and 2 (each within the scatter of the next).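

In this assay, this position is not flat after all: the group of 12 heavy atoms gives a 3.6-fold lower number from compound 2 to compound 3 (0.56 log units; beyond the scatter), and against the methoxy-bearing group it gives a 3.6-fold lower number from compound 1 to compound 3 (0.56 log units; beyond the scatter). Among these compounds, the earlier exchange of methylsulfanyl for methoxy gave only no change at the digits printed from compound 1 to compound 2 (within the scatter), so the larger group with both sulfurs retained is the first change here to move the number beyond the scatter. Nothing in hand accounts for the lower number.

Open, from the compounds shown here alone, is whether one ethylsulfanyl group alone suffices, with methylsulfanyl in the other place. Also open, going by these compounds, is whether a longer chain, such as propylsulfanyl, continues the trend.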